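The source may report more compounds than this note shows. Statements on the series, on what has been measured and on what is new or still open speak of the compounds shown alone.

Measured compounds:
- compound 1, `C[C@H](NC(=O)Nc1ccccc1Cl)c1ccccc1`: 106%
- compound 2, `C[C@@H](NC(=O)Nc1cccc(Cl)c1)c1ccccc1`: 83%
- compound 3, `C[C@H](NC(=O)Nc1ccccc1Br)c1ccccc1`: 102%

All three were run in an ADME assay on the whole organism with Oryza sativa as the target, tested at 10 uM; on this read-out lower numbers stand for a stronger effect and higher numbers for a weaker effect at the one concentration tested. Compound 1 gives 106%, compound 3 gives 102%, and compound 2 gives 83%, the lowest of the three numbers and beyond the scatter from both others. Compound 1 and compound 2 share the same atoms joined differently; the difference between the two cores is not broken down here.

Compound 1 and compound 3 differ in one place: bromo in place of chloro on an aromatic carbon. That change gave a number 4 percentage points lower from compound 1 to compound 3 (within the scatter), a step within the scatter, so the two numbers cannot be ordered.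

Compound 4, `C[C@@H](NC(=O)Nc1cccc(Br)c1)c1ccccc1`, is not yet measured. It stands to compound 2 as compound 3 stands to compound 1: bromo in place of chloro on an aromatic carbon. The change is the same kind of change, not the same one, since the place differs: in the pair of compound 1 and compound 3 the halogen sits ortho to a large group, whereas in the pair of compound 2 and compound 4 it sits meta to a large group. Among the compounds with values here, the only guide is the one measured example of this kind, so the expectation is a small step, a number 3 percentage points lower from compound 2 to compound 4 (within the scatter), resting on compound 1 and compound 3 showing a number 4 percentage points lower from compound 1 to compound 3 (within the scatter). For compound 4 the estimate in this assay is 80%, with a range from 66% to 94%.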

Compound 4, a percentage reported as activity, at one concentration (the size of the read-out at that concentration, not a potency): 99%
Compound 4: the middle estimate sits 19 percentage points below what was measured; measured number above the stated range.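

In this assay, bromo in place of chloro, meta to a large group, gives a number 16 percentage points higher from compound 2 to compound 4 (beyond the scatter), and this step does not match the earlier one, so the change does not carry over unchanged between these two cores: the same change on two cores in this assay, a number 4 percentage points lower (within the scatter) from compound 1 to compound 3 and a number 16 percentage points higher (beyond the scatter) from compound 2 to compound 4, 20 percentage points apart, beyond the scatter of two such steps. For this series, a step measured for this swap on one core is therefore a poor guide to the step on another, and the size and even the direction of the step have to be measured on each core. Within the data shown here, the result does not show what separates the two cores, since the data rest on only two matched pairs and do not say whether the place of the halogen or some other difference between the cores accounts for the gap, nor do they say how the swap would behave on a third core.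

The compounds shown leave open how fluoro, methoxy, a nitrile or an amine would read in place of the halogen on either core. Also open, going by these compounds, is whether a longer chain in place of the methyl group would alter the number on either core, or the size of the halogen step.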